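Amide variation on the shared core: compound 3 to compound 4

This account rests on a few compounds, and the source may have more. Where it says the series, first, only, none or still open, it means among the compounds named here.

compound 1 `Nc1sc(-c2ccc(Cl)cc2)c(-c2ccc(Cl)cc2)c1C(=O)NC1CCCCC1` gives 7300 nM
compound 2 `Nc1sc(-c2ccc(Cl)cc2)c(-c2ccc(Cl)cc2)c1C(=O)N1CCOCC1` gives 11700 nM
compound 3 `CN1CCN(C(=O)c2c(N)sc(-c3ccc(Cl)cc3)c2-c2ccc(Cl)cc2)CC1` gives 13100 nM

In a functional assay on PC-3 cells (Homo sapiens) for inhibition, read by sulforhodamine B assay, with a stated time of 72 h (on this read-out lower numbers stand for stronger inhibition and higher numbers for weaker inhibition), compound 3 stands within the scatter of both other compounds, and the three values show no order. The measured steps are a 1.6-fold higher number from compound 1 to compound 2 (0.20 log units; within the scatter), a 1.8-fold higher number from compound 1 to compound 3 (0.25 log units; within the scatter) and a 1.1-fold higher number from compound 2 to compound 3 (0.05 log units; within the scatter), all within the scatter. Next is compound 4 `Nc1sc(-c2ccc(Cl)cc2)c(-c2ccc(Cl)cc2)c1C(=O)NC1CCCC1`, with cyclopentylamino in place of 4-methylpiperazin-1-yl on a carbonyl carbon. The closest measured step is a 1.8-fold higher number from compound 1 to compound 3 (0.25 log units; within the scatter), with cyclohexylamino on the same carbonyl carbon. No step beyond the scatter is therefore expected in this assay, with at most a slightly lower number. The estimated step is a 1.6-fold lower number from compound 3 to compound 4 (0.21 log units; within the scatter) and stays within the scatter. For compound 4 the expected value is 8000 nM, with an estimated range of 4000 nM to 15000 nM overall.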

Compound 4, half-maximal inhibitory concentration: 21200 nM
For compound 4 the middle estimate is 2.7-fold (0.42 log units) below the measured one; the whole stated range lies below it.
By their numbers in this assay, from the lowest: compounds 1, 2, 3 and 4 (each within the scatter of the next, the first and the last beyond it).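

In this assay the step of a 1.6-fold higher number from compound 3 to compound 4 (0.21 log units; within the scatter) and the step of a 1.8-fold higher number from compound 2 to compound 4 (0.26 log units; within the scatter) leave cyclopentylamino unseparated from 4-methylpiperazin-1-yl and morpholin-4-yl on the carbonyl carbon. Going by these compounds alone, the only step beyond the scatter, and a modest one, is a 2.9-fold higher number from compound 1 to compound 4 (0.46 log units; beyond the scatter) with cyclopentyl in place of cyclohexyl on an amide-type nitrogen. Ring size on that nitrogen therefore registers in this small set, which none of the earlier swaps did. Open, from the compounds shown here alone, is whether cycloheptyl or an open-chain butyl on that nitrogen would extend this difference. No measurement at hand accounts for the step.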